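Urea-to-amide change on the pyridyl-pyrazole urea series

The source may report more compounds than this note shows. Statements on the series, on what has been measured and on what is new or still open speak of the compounds shown alone.

Measured so far in a functional assay on NCI-H522 cells (Homo sapiens) for inhibition, read by sulforhodamine B assay, with a stated time of 48 h, tested at 0.1 uM; a lower number here means a stronger effect, a higher number a weaker effect of the compound at the concentration tested:

compound 1, `O=C(Nc1cccc(-n2cc(-c3ccncc3)c(-c3cc(O)cc(Cl)c3)n2)c1)Nc1ccc(Cl)c(Cl)c1`, gives 92%
compound 2, `COc1cc(Cl)cc(-c2nn(-c3cccc(NC(=O)Nc4cc(C(F)(F)F)cc(C(F)(F)F)c4)c3)cc2-c2ccncc2)c1`, gives 80%
compound 3, `COc1cc(Cl)cc(-c2nn(-c3cccc(NC(=O)Nc4ccc(Cl)c(Cl)c4)c3)cc2-c2ccncc2)c1`, gives 53%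

Compound 3 stands lowest of the three values, with compound 2 and compound 1 both higher, beyond the scatter in each case, so compound 3 shows the strongest effect of the measured set. For the measured compounds named here, the only single-point step is a number 39 percentage points lower from compound 1 to compound 3 (beyond the scatter), which concerns the oxygen substituent on the shared core and not the urea end of the molecule.

Compound 4, `COc1cc(Cl)cc(-c2nn(-c3cccc(NC(=O)c4cccc(C(F)(F)F)c4)c3)cc2-c2ccncc2)c1`, is not yet measured. It differs from compound 3 as follows: 3-(trifluoromethyl)phenyl in place of (3,4-dichlorophenyl)amino on a carbonyl carbon. The urea of compound 3 becomes an amide, and the hydrogen-bond donor counted for the leaving group is gone. Going by the values given here, no measured step touches this part of the structure; compound 2 and compound 3 differ in the aryl on the urea, and their two values show a difference beyond the scatter, but that is a swap of aryl groups, not a change of the linking group itself.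

The expectation therefore rests on weak ground. For compound 4 in this assay the estimate is 75%, within 50% to 98%, which means an expected step of a number 22 percentage points higher from compound 3 to compound 4 (beyond the scatter) toward a weaker effect, with the range wide enough to include no change beyond the scatter.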

Compound 4, a percentage reported as activity, at one concentration (the size of the read-out at that concentration, not a potency): 83%
Compound 4: the middle estimate sits 8 percentage points below what was measured; the range from low to high includes it.
By their numbers in this assay, from the lowest: compound 3; then compounds 2, 4 and 1 (each within the scatter of the next, the first and the last beyond it).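

In this assay, the change from urea to amide at this position gives a number 30 percentage points higher from compound 3 to compound 4 (beyond the scatter), so the weaker effect now extends to a change in the link itself and not only to the oxygen substituent on the shared core. The step replaces two features at once: the nitrogen of the urea goes, along with the hydrogen-bond donor counted for the leaving group, and the aryl changes from 3,4-dichlorophenyl to 3-(trifluoromethyl)phenyl, so this one comparison cannot assign the loss to either feature alone. Nothing available here gives a measured reason for the step.

The compounds shown leave open whether an amide carrying the 3,4-dichlorophenyl group on the carbonyl carbon, or a urea carrying 3-(trifluoromethyl)phenyl, would keep the value of compound 3 at 53%, and either compound would separate the link from the aryl. Also open, going by these compounds, is how other links at this place, such as a sulfonamide or a carbamate, would read at this single concentration.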